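The compounds below may be only part of what the source reports. "The series", "measured", "known", "first", "only" and "open" are said of these compounds alone.

Of the compounds shown here, two have been measured so far in an assay on isolated protein for inhibition of Amine oxidase [flavin-containing] A (Homo sapiens); a higher number here means a weaker inhibitor, a lower number a stronger inhibitor. Compound 1, with the structure `CN(Cc1ccccc1)Cc1cc2ccccc2[nH]1`, gives 60000000 nM in this assay. Compound 2, with the structure `c1ccc(CNCc2ccc[nH]2)cc1`, gives 350000000 nM in this assay, the highest of the two numbers, and its gap to compound 1 lies beyond the usual scatter of repeated measurements. Compound 1 and compound 2 differ in more than one place, so no single structural change can be read from that gap.

The next compound, compound 3, has the structure `CN(Cc1ccccc1)Cc1ccc[nH]1` and has not yet been measured in this assay. It differs from compound 2 in one place: methyl in place of hydrogen on an amine nitrogen. Compound 1 also carries a methyl on its amine nitrogen, which is the only hint available about this change, though its ring system differs as well. On this thin basis the step from compound 2 to compound 3 in this assay is expected to be downward, perhaps by a 2.3-fold lower number from compound 2 to compound 3 (0.37 log units; beyond the scatter), with little confidence. Compound 3 is therefore expected to give about 150000000 nM in this assay, somewhere between 40000000 nM and 500000000 nM.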

Compound 3, inhibition constant: 286000000 nM
The estimate for compound 3 lay 1.9-fold (0.28 log units) below the measured number; the measured number falls inside the stated range.
By their numbers in this assay, from the lowest: compound 1; then compounds 3 and 2 (each within the scatter of the next).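

In this assay, putting methyl in place of hydrogen on this amine nitrogen gives a 1.2-fold lower number from compound 2 to compound 3 (0.09 log units; within the scatter), so the two compounds cannot be told apart in this assay. Going by these compounds alone, this is the first direct reading of the change, and it shows that a single added carbon at this position, on the shared core of compound 2 and compound 3, has no effect that can be separated from ordinary measurement scatter. Compound 1 also carries a methyl on its amine nitrogen but has a different core, and it gives 60000000 nM; the methyl step seen here therefore offers no support for attributing that value to the methyl.

On these data alone, whether this nitrogen tolerates substituents generally remains open, since an ethyl group, a longer chain or an acetyl group at the same place could behave differently from methyl. Nothing available explains why the methyl leaves the number within the scatter, and no independent measurement bears on this result.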